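Working notes: chloro in place of methoxy, compound 1 to compound 4

This account rests on a few compounds, and the source may have more. Where it says the series, first, only, none or still open, it means among the compounds named here.

Measured in a functional assay on HCC 2998 cells (Homo sapiens) for inhibition, read by sulforhodamine B assay, with a stated time of 48 h; on this read-out higher numbers stand for weaker inhibition of growth and lower numbers for stronger inhibition of growth:

compound 1 : `COc1ccc(-c2ccc(-c3ccc(C(=N)N)cc3)s2)cc1`, 1330 nM
compound 2 : `N=C(N)c1ccc(-c2ccc(-c3cc(Cl)cc(Cl)c3)s2)cc1`, 634 nM
compound 3 : `COc1ccc(-c2ccc(-c3ccc(C(=N)N)c(F)c3)s2)cc1`, 1850 nM

Compound 1 stands second highest of the three numbers. Its nearest neighbour is compound 3: the step of a 1.4-fold higher number from compound 1 to compound 3 (0.14 log units; within the scatter) lies within the scatter, so the two are not distinguished. Compound 2 gives the lowest number, and the gap from compound 1 to compound 2 is beyond the scatter.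

Compound 4 is `N=C(N)c1ccc(-c2ccc(-c3ccc(Cl)cc3)s2)cc1`. Relative to compound 1 the change is chloro in place of methoxy on an aromatic carbon.

Among the compounds with values here, the only measured single-place step in this assay , from compound 1 to compound 3, concerns fluoro in place of hydrogen at a different place, and does not bear directly on the methoxy-to-chloro change. Compound 2, which carries chloro groups and no methoxy, gives the lowest number of the three, but it is not a single-place comparison with compound 1. Within the data shown here, with no direct precedent, a modest lower number is expected, a 1.4-fold lower number from compound 1 to compound 4 (0.15 log units; within the scatter), likely within the scatter.

Compound 4 is estimated at 950 nM in this assay , within 400 nM to 2200 nM.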

Compound 4, concentration for 50% growth inhibition: 183 nM
Compound 4: the middle estimate sits 5.2-fold (0.72 log units) above what was measured, and the stated range ends above it.
By their numbers in this assay, from the lowest: compound 4; then compound 2; then compounds 1 and 3 (each within the scatter of the next).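

Working notes: in this assay, chloro in place of methoxy on an aromatic carbon, para to a large group, gives a clear change, a 7.3-fold lower number from compound 1 to compound 4 (0.86 log units; beyond the scatter), whereas the only earlier single-place step, a 1.4-fold higher number from compound 1 to compound 3 (0.14 log units; within the scatter), stayed within the scatter at a different place. Within the data shown here, this position therefore responds to the group it carries, at least for this pair, and the size of the step could not be read from the earlier compounds. Nothing on hand explains the lower number.

From the compounds shown here alone, whether the lower number follows from chloro entering or methoxy leaving stays open, and hydrogen at this position would separate the two. Also open, going by these compounds, are how an amine or a trifluoromethyl group would read at the same place, and whether the step holds with the fluoro of compound 3 present.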